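Swapping Iodine for Fluorine on an Aromatic Carbon

The compounds below may be only part of what the source reports. "The series", "measured", "known", "first", "only" and "open" are said of these compounds alone.

Three compounds that share an unsaturated acid carrying a thiol have been measured in an assay on isolated protein for inhibition of Calpain-1 catalytic subunit (Sus scrofa), read by FRET; on this read-out lower numbers stand for stronger inhibition and higher numbers for weaker inhibition. Compound 1 `O=C(O)/C(S)=C/c1c[nH]c2cc(Cl)ccc12` gives 210 nM, compound 3 `O=C(O)/C(S)=C/c1c[nH]c2c(Br)cccc12` gives 2 nM, and compound 2 `O=C(O)/C(S)=C/c1ccc(I)cc1` gives 2200 nM. Compound 2 therefore shows the highest number of the three: its number lies above that of compound 1 and far above that of compound 3, both gaps reaching beyond the usual scatter, so compound 2 is the weakest inhibitor in this small set.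

Compound 4 `O=C(O)/C(S)=C/c1ccc(F)cc1` has not yet been measured. It differs from compound 2 in one place: fluoro in place of iodo on an aromatic carbon. Among the measured compounds shown here, no measured pair in this set isolates an exchange of this kind, so there is no directly comparable step to lean on. Since compound 2 already sits at the weak end with 2200 nM, a modest shift toward a still higher number, or no shift beyond the scatter, is expected. This expectation corresponds to a step of a 1.8-fold higher number from compound 2 to compound 4 (0.26 log units; within the scatter). Compound 4 is expected to give about 4000 nM, within a range from 1500 nM to 12000 nM.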

Compound 4, half-maximal inhibitory concentration: 6900 nM
Estimate against measurement, compound 4: 1.7-fold (0.24 log units) below, within the range that was stated.
By their numbers in this assay, from the lowest: compound 3; then compound 1; then compound 2; then compound 4.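

On a six-membered aromatic ring of carbon only, the group para to a group of 6 heavy atoms clearly affects the result: in this assay, fluoro in place of iodo gives a 3.1-fold higher number from compound 2 to compound 4 (0.50 log units; beyond the scatter). Among the compounds shown here, this is the first comparison here in which only one place changes, and it shows that keeping iodo gives stronger inhibition, although the effect is modest. The exchange replaces one heavy atom with one heavy atom and leaves the hydrogen-bond donor, acceptor and net charge counts unchanged, but no measurement here explains the difference between these two halogens.

The compounds shown leave open where chloro or bromo would fall at this same place, and how an amine or a methoxy group would compare. They also do not show whether the same exchange would have a similar effect on the core of compound 1.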